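Swapping the Aryl Group on a Piperazine Nitrogen

The source may report more compounds than this note shows. Statements on the series, on what has been measured and on what is new or still open speak of the compounds shown alone.

Compound 3 `CCCc1nc(-c2ccccc2)c(CNCCN2CCN(c3ccc(C(F)(F)F)cc3)CC2)o1` was tested in an assay on HEK293 cells for inhibition of Voltage-dependent T-type calcium channel subunit alpha-1G (Homo sapiens), read by fluorescence, tested at 10 uM (a lower number here means less inhibition, a higher number more inhibition at the concentration tested (going by the name of the read-out)), where compound 3 gives 58.7%. Compound 2 `CCCc1nc(-c2ccccc2)c(CNCCN2CCN(c3ccc(F)cc3)CC2)o1` gives 54.1% and compound 1 `CCCc1nc(-c2ccccc2)c(CNCCN2CCN(c3ccccc3C)CC2)o1` gives 51.3%, so compound 3 carries the highest of the three numbers, yet the steps of a number 4.6 percentage points higher from compound 2 to compound 3 (within the scatter) and a number 7.4 percentage points higher from compound 1 to compound 3 (within the scatter) are both within the scatter, as is a number 2.8 percentage points higher from compound 1 to compound 2 (within the scatter). Compound 4 `CCCc1nc(-c2ccccc2)c(CNCCN2CCN(c3cccc(C)c3)CC2)o1` differs from compound 3 in one place: 3-methylphenyl in place of 4-(trifluoromethyl)phenyl on an amine nitrogen in a ring. Within the data shown here, no measured step makes exactly this exchange; the closest, the step of a number 7.4 percentage points higher from compound 1 to compound 3 (within the scatter), changed one aryl group on the ring nitrogen for another and stayed small. Since every aryl group tried so far gave a number within the scatter of the others, the step of a number 5.7 percentage points lower from compound 3 to compound 4 (within the scatter) is expected to be no larger. Compound 4 is therefore estimated at 53%, within a range from 40% to 66%.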

Compound 4, a percentage reported as inhibition, at one concentration (the size of the read-out at that concentration, not a potency): 43.1%
Compound 4: the middle estimate sits 9.9 percentage points above what was measured; measured number inside the range.
By their numbers in this assay, from the lowest: compounds 4, 1, 2 and 3 (each within the scatter of the next, the first and the last beyond it).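

This position can shift the number after all: in this assay the step of a number 15.6 percentage points lower from compound 3 to compound 4 (beyond the scatter) and the step of a number 11 percentage points lower from compound 2 to compound 4 (beyond the scatter) both lie beyond the scatter, which no earlier aryl exchange did. The step of a number 8.2 percentage points lower from compound 1 to compound 4 (within the scatter) stays within the scatter, so the two methylphenyl groups cannot be told apart here. Nothing available explains why the exchanges differ in size. Still open, going by these compounds, is how an unsubstituted phenyl group, a pyridyl group or a phenyl group carrying an amine or a carboxylic acid would fare on this ring nitrogen.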